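Moving the Hydroxy Group from Compound 3 to Compound 4

The source may hold more compounds than are shown below. What is called first, only, known or untested is meant among the compounds shown, and "the series" means these compounds.

In a functional assay on the whole organism (strain Wistar) for inhibition, with Rattus norvegicus as the target, read by paw edema, with a stated time of 2 h, at a dose of 10 mg/kg by the intraperitoneal route (on this read-out higher numbers stand for more inhibition at the one dose given (going by the name of the read-out) and lower numbers for less inhibition), compound 1 `O=C(N/N=C/c1ccccc1)c1cccnc1Nc1cccc(C(F)(F)F)c1` gives 36.8%, compound 2 `O=C(N/N=C/c1ccc(Cl)cc1)c1cccnc1Nc1cccc(C(F)(F)F)c1` gives 52.8%, and compound 3 `O=C(N/N=C/c1cccc(O)c1)c1cccnc1Nc1cccc(C(F)(F)F)c1` gives 65.4%, the highest of the three. The step of a number 28.6 percentage points higher from compound 1 to compound 3 (beyond the scatter) and the step of a number 12.6 percentage points higher from compound 2 to compound 3 (beyond the scatter) both end at compound 3. Compound 4 `O=C(N/N=C/c1ccc(O)cc1)c1cccnc1Nc1cccc(C(F)(F)F)c1` differs from compound 3 by 4-hydroxyphenyl in place of 3-hydroxyphenyl on a carbon with a double bond to nitrogen. Among the measured compounds shown here, no measured step exchanges 3-hydroxyphenyl for 4-hydroxyphenyl, so the measured steps bear only loosely here: they show that a hydroxy on that ring goes with the higher numbers. A small step is therefore expected, likely within the scatter, a number 5.4 percentage points lower from compound 3 to compound 4 (within the scatter). Compound 4 is estimated at 60%, with a range from 45% to 75%.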

Compound 4, a percentage reported as inhibition, in the whole organism at one dose (the size of the read-out at that dose, not a potency): 68%
For compound 4 the middle estimate is 8 percentage points below the measured one; the range from low to high includes it.
By their numbers in this assay, from the lowest: compound 1; then compound 2; then compounds 3 and 4 (each within the scatter of the next).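

Swapping in 4-hydroxyphenyl for 3-hydroxyphenyl gives a number 2.6 percentage points higher from compound 3 to compound 4 (within the scatter) in this assay, so this read-out does not separate the two hydroxyphenyl groups. The gain also holds for 4-hydroxyphenyl: hydrogen replaced by hydroxy gives a number 31.2 percentage points higher from compound 1 to compound 4 (beyond the scatter) on this ring, and chloro replaced by hydroxy gives a number 15.2 percentage points higher from compound 2 to compound 4 (beyond the scatter) here as well. Nothing available explains these numbers.

Going by these compounds, whether a methoxy group or an amine on this ring would match the hydroxy remains open. So does the effect of a carboxylic acid there.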